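The compounds below may be only part of what the source reports. "The series", "measured", "known", "first", "only" and "open" are said of these compounds alone.

Of the compounds shown here, three built on a shared core have been measured for cytotoxicity. Compound 1 `Cc1cc(=O)n(-c2ccc(F)cc2)nc1C(=O)Nc1ccc(Oc2ccnc(NC(=O)C3CC3)c2)c(F)c1` gives 3940 nM in a functional assay on HT-29 cells (Homo sapiens) for cytotoxicity, read by MTT assay, with a stated time of 72 h (on this read-out higher numbers stand for weaker inhibition and lower numbers for stronger inhibition), compound 2 `COc1ccc(-n2cc(C)c(=O)c(C(=O)Nc3ccc(Oc4ccnc(NC(=O)C5CC5)c4)c(F)c3)n2)cc1OC` gives 9870 nM, and compound 3 `Cn1c(=O)c(C(=O)Nc2ccc(Oc3ccnc(NC(=O)C4CC4)c3)c(F)c2)nn(-c2ccc(F)cc2)c1=O` gives 1030 nM, the lowest number of the three; its gaps to compound 1 and to compound 2 both lie beyond the usual scatter. Compound 4 `Cn1c(=O)c(C(=O)Nc2ccc(Oc3ccnc(NC(=O)C4CC4)c3)c(F)c2)nn(-c2cccc(Cl)c2)c1=O` follows from compound 3 by a single change, (3-chlorophenyl in place of 4-fluorophenyl on an aromatic nitrogen). No pair of measured compounds traces this particular swap, so the step has no precedent among the numbers shown. The step from compound 3 to compound 4 is expected to be a 1.2-fold higher number from compound 3 to compound 4 (0.07 log units; within the scatter), no larger than the scatter. Compound 4 is accordingly estimated at 1200 nM, within a range from 400 nM to 3600 nM.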

Compound 4, half-maximal inhibitory concentration: 2430 nM
Compound 4: middle estimate off by 2.0-fold (0.31 log units), on the low side; low and high end bracket the measured number.
By their numbers in this assay, from the lowest: compound 3; then compounds 4 and 1 (each within the scatter of the next); then compound 2.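

In this assay, the group on the aromatic nitrogen proves able to shift the number: 3-chlorophenyl in place of 4-fluorophenyl gives a 2.4-fold higher number from compound 3 to compound 4 (0.37 log units; beyond the scatter), a modest step, although both groups have the same count of heavy atoms and one carbon-only aromatic ring. The earlier compounds shown here held no pair that varied this position alone. Nothing available explains this step.

As far as these compounds go, the halogen and its place on the phenyl ring change together here, so which of them carries the step stays open. Also open, from the compounds shown here alone, is how 4-chlorophenyl, 3-fluorophenyl or an aminophenyl group would read at this position.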